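The source may hold more compounds than are shown below. What is called first, only, known or untested is meant among the compounds shown, and "the series" means these compounds.

Measured compounds:
- compound 2, `CNc1nc(-n2cc(CC3CCCC3)nn2)nc2c1ncn2[C@@H]1O[C@H](CO)[C@@H](O)[C@H]1O`, in an assay on CHO cells for displacement of a labelled ligand from adenosine receptor A3 (Rattus norvegicus) (on this read-out higher numbers stand for weaker inhibition and lower numbers for stronger inhibition), gives 312 nM.
- compound 1, `CNc1nc(-n2cc(-c3ccccn3)nn2)nc2c1ncn2[C@@H]1O[C@H](CO)[C@@H](O)[C@H]1O`, in this assay reaches only the limit > 10000 nM.

Among the compounds with values here, compound 2 thus holds the only actual number in this assay; the other entry is a limit, (the limit of > 10000 nM in this assay, at which 1 of the 2 values shown sits). Within the data shown here, the one measured step, an at least 32-fold lower number from compound 1 to compound 2 (1.50 log units; beyond the scatter), replaced pyridin-2-yl on an aromatic carbon with cyclopentylmethyl. The next step leads to compound 3, `CNc1nc(-n2cc(Cc3ccccc3)nn2)nc2c1ncn2[C@@H]1O[C@H](CO)[C@@H](O)[C@H]1O`, with phenyl in place of cyclopentyl on a saturated chain carbon bound to an aromatic carbon. That change keeps the saturated chain carbon and swaps only the ring on it, so it does not repeat the measured step, which changed both linker and ring at once; the measured step bears on it only loosely. Compound 3 is therefore expected to stay in the same region as compound 2, with a step of a 1.9-fold higher number from compound 2 to compound 3 (0.28 log units; within the scatter) and a modest drift toward weaker inhibition. In this assay compound 3 is expected to give about 600 nM, within 150 nM to 3000 nM.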

Compound 3, inhibition constant: 1790 nM
Estimate against measurement, compound 3: 3.0-fold (0.47 log units) below, within the range that was stated.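

In this assay, the ring on the saturated chain carbon matters on its own: with that carbon kept, phenyl in place of cyclopentyl gives a 5.7-fold higher number from compound 2 to compound 3 (0.76 log units; beyond the scatter). The other new step, an at least 5.5-fold lower number from compound 1 to compound 3 (0.74 log units; beyond the scatter), shows that an aromatic ring held on a saturated chain carbon still gives an actual number, as the cyclopentyl ring does in compound 2. Compound 1 remains a limit and not a number, so this step has only a lower bound: the limit of > 10000 nM in this assay, at which 1 of the 3 values shown sits.

The compounds shown do not separate the effect of the saturated chain carbon from that of the ring nitrogen of pyridin-2-yl, a question that phenyl directly on the aromatic carbon would address. From the compounds shown here alone, how a longer chain, or an amine on the ring, would read in this assay also stays open.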